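Working notes: from compound 3 to compound 4

The compounds below may be only part of what the source reports. "The series", "measured", "known", "first", "only" and "open" are said of these compounds alone.

Measured so far in an ADME assay on HEL cells (Homo sapiens) for cytotoxicity; on this read-out higher numbers stand for lower toxicity in this test and lower numbers for higher toxicity in this test
- compound 1 `O=C(COc1cccc2ccccc12)N/N=C/c1ccc(Br)cc1` gives 100 ug/mL
- compound 2 `O=C(COc1cccc2ccccc12)N/N=C/c1ccccc1O` gives 3.57 ug/mL
- compound 3 `O=C(COc1cccc2ccccc12)N/N=C/c1cccc(Br)c1` gives 48.6 ug/mL

Compound 3 stands second highest of the three numbers, with compound 1 nearest on the high side and compound 2 much further off on the low side. The next entry is compound 4 `Cc1ccc(/C=N/NC(=O)COc2cccc3ccccc23)cc1` with 4-methylphenyl in place of 3-bromophenyl on a carbon with a double bond to nitrogen. No exchange of bromine for methyl has been measured, so the evidence is indirect. The closest measured step is the change from 4-bromophenyl to 3-bromophenyl (a 2.1-fold lower number from compound 1 to compound 3 (0.31 log units; beyond the scatter)), which is modest and only just beyond the scatter. The two large steps (a 28-fold lower number from compound 1 to compound 2 (1.45 log units; beyond the scatter)) and (a 14-fold higher number from compound 2 to compound 3 (1.13 log units; beyond the scatter)) both involve 2-hydroxyphenyl, a group that plays no part in this change, so they carry little weight here. In this assay no step beyond the scatter is therefore expected, with a slight upward lean as the estimated outcome (a 1.4-fold higher number from compound 3 to compound 4 (0.16 log units; within the scatter)). Compound 4 is estimated at 70 ug/mL with an expected range from 30 ug/mL to 100 ug/mL as the working figure.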

Compound 4, half-maximal cytotoxic concentration: 80.1 ug/mL
Compound 4: the middle estimate sits 1.1-fold (0.06 log units) below what was measured, within the range that was stated.
By their numbers in this assay, from the lowest: compound 2; then compounds 3, 4 and 1 (each within the scatter of the next, the first and the last beyond it).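

Notes on compound 4 in this assay: methyl in place of bromo on an aromatic carbon gives a 1.2-fold lower number from compound 1 to compound 4 (0.10 log units; within the scatter) and this is the first direct exchange of these two substituents, which this test does not separate at this place. The comparison with the other bromo compound gives a 1.6-fold higher number from compound 3 to compound 4 (0.22 log units; within the scatter) and this too stays within the scatter, so compound 4 lies within the scatter of both compound 1 and compound 3, even though those two bromo compounds are printed as just beyond the scatter of each other. Among these compounds, the step from the hydroxy compound gives a 22-fold higher number from compound 2 to compound 4 (1.35 log units; beyond the scatter) and this large gap leaves compound 2 as the only compound of the four set well apart from the others on this read-out. Nothing available on these compounds accounts for any of these steps.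

Still open, going by these compounds, is whether an amine or a carboxylic acid on this aromatic ring would give a number in the range of the bromo and methyl compounds or one closer to that of compound 2. Also open, on these data alone, is whether a longer chain in place of methyl would stay within the scatter of compound 4, and whether changes to the shared core would shift these numbers.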